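From sulfonyl to carbamoyl: compound 1 to compound 3

The source may hold more compounds than are shown below. What is called first, only, known or untested is meant among the compounds shown, and "the series" means these compounds.

In a functional assay on DU-145 cells (Homo sapiens) for inhibition, read by trypan blue exclusion, with a stated time of 72 h (a lower number here means a stronger inhibitor, a higher number a weaker inhibitor), compound 1 `Cn1c(=O)c(S(=O)(=O)c2ccc(Cl)cc2Cl)cc2cnc(Nc3ccc4[nH]ccc4c3)nc21` gives 1000 nM, level with compound 2 `Cn1c(=O)c(S(=O)(=O)Cc2ccc(F)cc2F)cc2cnc(Nc3ccc4[nH]ccc4c3)nc21` at 1000 nM. These two compounds are the only measured points in the series.

Compound 3 `Cn1c(=O)c(C(=O)Nc2ccc(F)cc2)cc2cnc(Nc3ccc4[nH]ccc4c3)nc21` differs from compound 1 at one place, with (4-fluorophenyl)carbamoyl in place of (2,4-dichlorophenyl)sulfonyl on an aromatic carbon.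

Within the data shown here, the only measured step is no change at the digits printed from compound 1 to compound 2 (within the scatter), with 2,4-difluorobenzyl in place of 2,4-dichlorophenyl on a sulfonyl sulfur. It bears only partly on the new change, since both of its compounds keep the sulfonyl, whereas compound 3 does not. Among the measured compounds shown here, no measured compound here carries a carbamoyl group, so the data give no direct reading for this exchange and no direction for a shift in this assay.

The working expectation therefore stays with compound 1 at 1000 nM, with no step beyond the scatter foreseen but with wide margins. The expected step is no change at the digits printed from compound 1 to compound 3 (within the scatter). For compound 3 the estimated value is 1000 nM, with an expected range of 300 nM to 4000 nM.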

Compound 3, half-maximal inhibitory concentration: 5000 nM
For compound 3 the middle estimate is 5.0-fold (0.70 log units) below the measured one; measured number above the stated range.
By their numbers in this assay, from the lowest: compounds 1 and 2 (each within the scatter of the next); then compound 3.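

In this assay, among these compounds, the group on this aromatic carbon matters: the exchange of (2,4-dichlorophenyl)sulfonyl for (4-fluorophenyl)carbamoyl gives a 5.0-fold higher number from compound 1 to compound 3 (0.70 log units; beyond the scatter) and is the first step beyond the scatter. Among the compounds shown here, the earlier step, no change at the digits printed from compound 1 to compound 2 (within the scatter) as the only other reading, kept the sulfonyl throughout, so it could not show what happens when that group itself is replaced. The present exchange alters the linking group and the substitution on the phenyl ring in a single step, and nothing available explains the higher number for compound 3.

Still open, on these data alone, is which part of the exchange carries the step: a (2,4-dichlorophenyl)carbamoyl group on the same aromatic carbon would keep the ring of compound 1 with the link of compound 3, and a (4-fluorophenyl)sulfonyl group would do the reverse. Also open, as far as these compounds go, is whether the aryl ring is needed at all on this carbon, which a dimethylcarbamoyl group or a carboxylic acid would test against the same shared core.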